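A Fluoro Step Repeated on a Second Core

This account rests on a few compounds, and the source may have more. Where it says the series, first, only, none or still open, it means among the compounds named here.

compound 1, `Fc1cc(Cl)ccc1-c1ccc(Cn2nnc3ccccc32)cn1`, in a functional assay on cells for positive allosteric modulation of metabotropic glutamate receptor 2 (Homo sapiens), read by fluorescence and calcium flux, with a stated time of 30 min (a lower number here means that less compound is needed, a higher number that more compound is needed for the effect), gives 50 nM
compound 2, `Fc1ccc2nnn(Cc3ccc(-c4ccc(Cl)cc4F)nc3)c2c1`, in this assay gives 86 nM
compound 3, `Clc1ccc(Cn2nnc3c(Br)cccc32)cc1`, in this assay gives 17 nM

Compound 3 shows the lowest number of the three. The difference between the core of compound 1 and the core of compound 3 is not broken down here. Compound 2 differs from compound 1 by fluoro in place of hydrogen on an aromatic carbon and that step was a 1.7-fold higher number from compound 1 to compound 2 (0.24 log units; within the scatter). Compound 4, `Fc1cc(Cl)ccc1Cn1nnc2c(Br)cccc21`, is not yet measured; it differs from compound 3 by fluoro in place of hydrogen on an aromatic carbon. This is the same kind of change, but the place differs: in compound 2 the fluoro sits on a ring that is part of a fused or bridged system of two rings, meta and para to a fused ring, whereas in compound 4 it sits on a six-membered aromatic ring of carbon only, ortho to a large group and meta to a chloro group. The expectation rests on compound 1 and compound 2, whose step was a 1.7-fold higher number from compound 1 to compound 2 (0.24 log units; within the scatter). For compound 4 the expected step in this assay is a 1.5-fold higher number from compound 3 to compound 4 (0.17 log units; within the scatter). Compound 4 is thus estimated at 25 nM, likely between 10 nM and 60 nM.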

Compound 4, half-maximal effective concentration: 23 nM
The estimate for compound 4 lay 1.1-fold (0.04 log units) above the measured number; low and high end bracket the measured number.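

The step on the second core is a 1.4-fold higher number from compound 3 to compound 4 (0.13 log units; within the scatter) in this assay. Set beside the step on the first core, the two agree: the same change on two cores in this assay, a 1.7-fold higher number (0.24 log units; within the scatter) from compound 1 to compound 2 and a 1.4-fold higher number (0.13 log units; within the scatter) from compound 3 to compound 4, 1.3-fold (0.10 log units) apart, within the scatter of two such steps

This shows that, on these two cores, fluoro in place of hydrogen on an aromatic carbon gives a step within the scatter each time, even though the fluoro sits at a different place on each core. It does not show that the change has a real effect of its own on either core, and two pairs say nothing about further cores.

On these data alone, whether a methoxy group or an amine in place of the same hydrogen would give a step beyond the scatter remains open.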